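The compounds below may be only part of what the source reports. "The series", "measured", "known", "first", "only" and "open" are said of these compounds alone.

Values so far in a functional assay on PANC-1 cells (Homo sapiens) for inhibition, read by XTT assay, with a stated time of 72 h; a higher number here means a weaker inhibitor, a lower number a stronger inhibitor
Compound 1 `CC(C)(C)OC(=O)N1CCC[C@H]1COCCCCCC/C=C/c1ccc(-c2ccccc2)cc1`: > 100000 nM (a limit of the assay, not a number)
Compound 2 `CC(C)(C)OC(=O)N1CCC[C@H]1COCCCCCC/C=C/c1ccc(Oc2ccccc2)cc1`: 63300 nM
Compound 3 `O=CN1CCC[C@H]1COCCCCCCCCC/C=C/c1ccc(-c2ccccc2)cc1`: 56700 nM

Going by the values given here, compound 2 at 63300 nM and compound 3 at 56700 nM are the only two true numbers here, and they lie within the usual scatter of each other. The next compound to consider is compound 4 `O=CN1CCC[C@H]1COCCCCCC/C=C/c1ccc(Oc2ccccc2)cc1` and it departs from compound 2 at one place. That change, from tert-butoxycarbonyl to formyl, is hydrogen in place of tert-butoxy on a carbonyl carbon and amounts to hydrogen in place of tert-butoxy on a carbonyl carbon.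

Among the compounds with values here, no measured step makes this exchange. Within the data shown here, the single step available is an at least 1.5-fold lower number from compound 1 to compound 2 (0.19 log units; that floor lies within the scatter) and it concerns phenoxy in place of phenyl on an aromatic carbon, not the carbonyl group, so it says little here. Compound 3 carries formyl and gives 56700 nM in the same range as compound 2, but it also differs from compound 4 in other places, which makes it only a loose guide.

On that basis, no step beyond the scatter is expected in this assay and the estimated move is a 1.4-fold lower number from compound 2 to compound 4 (0.15 log units; within the scatter) with wide uncertainty on either side. For compound 4 the expected value is 45000 nM with an estimated range from 14000 nM to 100000 nM until the measurement arrives.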

Compound 4, half-maximal inhibitory concentration: 53300 nM
Compound 4: the middle estimate sits 1.2-fold (0.07 log units) below what was measured; the measured number falls inside the stated range.
By their numbers in this assay, from the lowest: compounds 4, 3 and 2 (each within the scatter of the next). At a limit, above all of these: compound 1.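

In this assay, replacing tert-butoxy with hydrogen on the carbonyl carbon attached to the amide-type nitrogen in a ring, which turns tert-butoxycarbonyl into formyl, gives a 1.2-fold lower number from compound 2 to compound 4 (0.07 log units; within the scatter). Going by these compounds alone, this pair is the first direct reading at this position, and it shows that removing all of tert-butoxy makes no difference that can be told from the scatter of this assay, at least with this chain and the phenoxy group in place. The reading has little room at the weak end, because compound 1 already reaches a limit rather than a number: the limit of > 100000 nM in this assay, at which 1 of the 4 values shown sits.

The compounds shown leave open what a methyl group or an amine on that carbonyl carbon would do, and what a ring nitrogen carrying no carbonyl at all would do. They also leave open whether the same exchange would read alike with phenyl in place of phenoxy on this chain, as compound 3 carries formyl and phenyl but has a longer chain and so differs from compound 1 in more than one place.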